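The source may report more compounds than this note shows. Statements on the series, on what has been measured and on what is new or still open speak of the compounds shown alone.

Measured so far:
Compound 1, `O=c1c(-c2nn[nH]n2)c[nH]c2ccc(Cl)cc12`, gives > 25 mg/kg in a functional assay on the whole organism (strain Sprague-Dawley) for inhibition, with Rattus norvegicus as the target (on this read-out lower numbers stand for an effect already at smaller amounts and higher numbers for an effect only at larger amounts of compound), a limit of the assay rather than a number.
Compound 2, `Cc1ccc2[nH]cc(-c3nn[nH]n3)c(=O)c2c1`, gives > 25 mg/kg in this assay, again a limit.
Compound 3, `Cc1cc(F)c2[nH]cc(-c3nn[nH]n3)c(=O)c2c1`, gives > 10 mg/kg in this assay, also a limit.

Compound 2 therefore has no measured number of its own: it sits at the limit of > 25 mg/kg in this assay, at which 2 of the 3 values shown sit, and the two other values shown are limits as well, one of them at the limit of > 10 mg/kg in this assay, at which 1 of the 3 values shown sits. Compound 4, `CCc1ccc2[nH]cc(-c3nn[nH]n3)c(=O)c2c1`, is not yet measured. It differs from compound 2 in one place: methyl in place of hydrogen on a saturated chain carbon bound to an aromatic carbon. Going by the values given here, two measured steps touch compound 2. The step that the two limits leave unreadable from compound 1 to compound 2 and the step that the two limits leave unreadable from compound 2 to compound 3 are both unreadable; each ends at a limit on both sides, so neither tells how large a change of this kind is in this assay. Nothing measured here shows a step beyond the scatter, and nothing shows a step within it either; the values only say that none of the three compounds reached an effect at the doses tested. The expectation for compound 4 is therefore no readable step, and the estimated step of a number no higher from compound 2 to compound 4 (the limit leaves the size open) reflects that. Compound 4 is expected to give about 25 mg/kg in this assay, within 10 mg/kg to 60 mg/kg, most likely again reported only as a limit.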

Compound 4, minimum effective dose: 0.625 mg/kg
Compound 4: the middle estimate sits 40-fold (1.60 log units) above what was measured; measured number outside the range, below it.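

In this assay, one added methyl on a saturated chain carbon bound to an aromatic carbon turns a methyl into an ethyl and gives an at least 40-fold lower number from compound 2 to compound 4 (1.60 log units; beyond the scatter), so a change of a single carbon can matter far beyond the usual scatter. Replacing chloro with ethyl at that same place on the core gives an at least 40-fold lower number from compound 1 to compound 4 (1.60 log units; beyond the scatter), so among the three groups seen there, ethyl alone brings a measured effect on this read-out. The earlier steps cannot be read, which makes these two the first to show that this place on the core responds to change at all, and their size is only a minimum, set by a limit of the assay: the limit of > 25 mg/kg in this assay, at which 2 of the 4 values shown sit.

From the compounds shown here alone, whether the gain continues with a longer chain such as propyl, or what a branched isopropyl or a chain ending in an amine or a carboxylic acid would give here, stays open. Compound 3, which carries fluoro together with methyl, has only a limit of the assay, > 10 mg/kg, so what fluoro would do in compound 4 is also unknown.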